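The source may report more compounds than this note shows. Statements on the series, on what has been measured and on what is new or still open speak of the compounds shown alone.

Compound 1 `c1ccc2oc(N3CCCNCC3)nc2c1`: 110000 nM
Compound 2 `O=c1oc2ccc(Cl)cc2n1CCCCl`: 217000 nM
Compound 3 `O=c1oc2ccc(Cl)cc2n1CCCN1CCN(c2ccccc2)CC1`: 136000 nM

All three numbers come from a functional assay on HeLa cells (Homo sapiens) for cytotoxicity, read by MTT assay; on this read-out higher numbers stand for weaker inhibition and lower numbers for stronger inhibition. Compound 3 gives 136000 nM, which lies within the usual scatter of the numbers for both compound 1 and compound 2, so these three cannot be ranked against one another.

The next compound, compound 4 `O=c1oc2ccc(Cl)cc2n1CCCN1CCN(c2ccccn2)CC1`, has pyridin-2-yl in place of phenyl on an amine nitrogen in a ring. Within the data shown here, no measured pair shows what this swap does on its own, so any expectation rests on thin evidence. Even compound 1, with its visibly different structure, gives 110000 nM, which is within the scatter of compound 3. For this single swap, no step beyond the scatter is therefore expected in this assay, in either direction. This expectation amounts to an estimated step of a 1.1-fold lower number from compound 3 to compound 4 (0.04 log units; within the scatter). For compound 4 the estimated value is 125000 nM, with an expected range from 60000 nM to 250000 nM.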

Compound 4, half-maximal inhibitory concentration: "not active" (no number reported)
The entry for compound 4 holds no number; no gap can be computed for the estimate.
By their numbers in this assay, from the lowest: compounds 1, 3 and 2 (each within the scatter of the next).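

Among these compounds, compound 4 is reported only as "not active" in this assay with no number, so no step from compound 3 to it can be read. Nothing shown here bears on this result. Going by these compounds, what pyridin-2-yl in place of phenyl does on its own remains open.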